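The compounds below may be only part of what the source reports. "The series", "measured", "known", "first", "only" and "open" are said of these compounds alone.

Among the measured compounds shown here, compound 3 `COc1ccc(Sc2ccc(CC3=NCCN3)cc2)cc1` stands at the top of the numbers so far in an assay (Rattus norvegicus) for binding affinity to prostacyclin receptor (Homo sapiens), read by radioligand binding; on this read-out higher numbers stand for weaker inhibition and lower numbers for stronger inhibition: compound 3 gives 5010 nM. Its nearest neighbour, compound 1 `CC/N=C(\N)Nc1ccc(Sc2ccc(OC)cc2)cc1`, differs from it in one place, and in this assay compound 1 gives 251 nM. That single change produced a 20-fold higher number from compound 1 to compound 3 (1.30 log units; beyond the scatter). For the measured compounds named here, a third compound on the shared core, compound 2 `COc1ccc(Sc2ccc(NC3=NCCN3)cc2)cc1`, gives 50.1 nM; 50.1 nM (2 entries) in this assay, which sits well under both; no one-place step connects it to compound 3, so the two values are only set side by side here.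

Compound 4 `COc1ccc(Sc2ccc(C(=N)N)cc2)cc1` is not yet measured. It differs from compound 3 by a group of 3 heavy atoms (1 carbon, 2 nitrogen; no ring) in place of a group of 6 heavy atoms (4 carbon, 2 nitrogen; one five-membered non-aromatic ring with 2 hetero atoms), on an aromatic carbon. Going by the values given here, only one measured step bears on this: the move from compound 1 to compound 3 exchanged an acyclic nitrogen-rich group for the ring-bearing group, and the number rose sharply. Among the compounds with values here, compound 4 reverses that direction, returning to a short acyclic group without a ring, so a downward step in this assay is expected, though its size is uncertain because the new group is not the one seen in compound 1. The expected step for compound 4 is a 6.3-fold lower number from compound 3 to compound 4 (0.80 log units; beyond the scatter). Compound 4 is therefore estimated at 800 nM, within a range from 150 nM to 4000 nM.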

Compound 4, inhibition constant: 1260 nM
The estimate for compound 4 lay 1.6-fold (0.20 log units) below the measured number, and the stated range covers the measured number.
By their numbers in this assay, from the lowest: compound 1; then compound 4; then compound 3.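

Swapping the ring-bearing group on this aromatic carbon for the group of 3 heavy atoms with no ring gives a lower number in this assay, with a 4.0-fold lower number from compound 3 to compound 4 (0.60 log units; beyond the scatter), but this step recovers only part of the gap to the earlier acyclic group, as the change in the other direction from that group shows a 5.0-fold higher number from compound 1 to compound 4 (0.70 log units; beyond the scatter). The two groups without a ring thus differ from each other by more than the usual scatter, so at this position the lack of a ring does not by itself set the number, and the size and make-up of the acyclic group also matter. Nothing available here explains why these groups rank as they do.

Going by these compounds, it remains open how a simple amine or a carboxylic acid on this same aromatic carbon would compare with these groups. A longer carbon chain placed between the aromatic ring and the group of 3 heavy atoms is also untested in what is shown, so it is unknown whether the number would rise or fall.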